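This account rests on a few compounds, and the source may have more. Where it says the series, first, only, none or still open, it means among the compounds named here.

Compound 1 `Nc1nc(NC2CC2)c2ncn(/C=C3/CC3(CO)CO)c2n1`: 71500 nM
Compound 2 `CCCCCOc1nc(N)nc2c1ncn2/C=C1/CC1(CO)CO`: > 20000 nM

Within the data shown here, in an ADME assay on BCBL1 cells (Homo sapiens) for cytotoxicity, with a stated time of 7 days (a higher number here means that more compound is tolerated, a lower number that less compound is tolerated), compound 1 gives 71500 nM, the only number in this set. Compound 2 gives only a limit of the assay, > 20000 nM. Among the measured compounds shown here, the single measured step, a step that the limit leaves unreadable from compound 1 to compound 2, cannot be read because of the limit of > 20000 nM in this assay, at which 1 of the 2 values shown sits, so its size stays unknown.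

Compound 3 `CSc1nc(N)nc2c1ncn2/C=C1/CC1(CO)CO` differs from compound 1 by methylsulfanyl in place of cyclopropylamino on an aromatic carbon. For the measured compounds named here, the measured step concerns pentyloxy, not methylsulfanyl, and is unreadable anyway, so no measured step bears directly on this change; the data give no size and no direction for it. The account therefore rests on compound 1 alone. Compound 3 is expected to stay close to compound 1, with an estimate of 55000 nM and a range from 15000 nM to 150000 nM. The step of a 1.3-fold lower number from compound 1 to compound 3 (0.11 log units; within the scatter) thus expected lies within the usual scatter.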

Compound 3, half-maximal cytotoxic concentration: > 20000 nM
Compound 3: no number, only a limit (the forecaster's own chance of this, stated with the estimate: 30%); the middle value does not contradict the limit.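

In this assay compound 3 gives only a limit of the assay (> 20000 nM). Its steps from compound 1 and compound 2 therefore cannot be read: (the limit of > 20000 nM in this assay, at which 2 of the 3 values shown sit). The compounds shown leave open whether methylsulfanyl or pentyloxy in place of cyclopropylamino changes how much compound is tolerated, and in which direction.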